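The source may report more compounds than this note shows. Statements on the series, on what has been measured and on what is new or still open speak of the compounds shown alone.

Measured so far:
compound 1, `Cc1cc(NCCN2CCN(C)CC2)nc2ccc(NC(=O)c3ccc(Cl)c(Cl)c3)cc12`: 1700 nM
compound 2, `CCN1CCN(c2cc(C)c3cc(NC(=O)c4cccc(F)c4)ccc3n2)CC1`: 8920 nM

In a functional assay on MCF7 cells (Homo sapiens) for antiproliferative activity, read by MTT assay, with a stated time of 72 h (a higher number here means a weaker inhibitor, a lower number a stronger inhibitor), compound 1 gives 1700 nM, the lower of the two numbers. Compound 2 gives 8920 nM in this assay, a higher number beyond the usual scatter. For the measured compounds named here, compound 2 differs from compound 1 in several places at once, so the two values show only that compound 1 is the stronger inhibitor of this pair, not which change accounts for the gap.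

Compound 3, `Cc1cc(N2CCCCC2)nc2ccc(NC(=O)c3ccc(Cl)c(Cl)c3)cc12`, has not yet been measured in this assay. It differs from compound 1 in one place: piperidin-1-yl in place of (2-(4-methylpiperazin-1-yl)ethyl)amino on an aromatic carbon. The change sits on the aromatic carbon next to the ring nitrogen, para to a fused ring. Going by the values given here, no measured pair reports the effect of such a change, so the expected step rests on the structural change alone. A step toward a higher number, somewhat beyond the scatter, is expected: a 2.6-fold higher number from compound 1 to compound 3 (0.42 log units; beyond the scatter). Compound 3 is therefore estimated at 4500 nM, with an expected range from 1500 nM to 15000 nM.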

Compound 3, half-maximal inhibitory concentration: 31100 nM
Beside the measured number, compound 3's estimate is 6.9-fold (0.84 log units) below it, outside the stated range (above it).
By their numbers in this assay, from the lowest: compound 1; then compound 2; then compound 3.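

In this assay, for the compounds shown here, the aromatic carbon next to the ring nitrogen proves sensitive to what it carries: piperidin-1-yl in place of (2-(4-methylpiperazin-1-yl)ethyl)amino gives an 18-fold higher number from compound 1 to compound 3 (1.26 log units; beyond the scatter) and this large step is the first single-place comparison. The swap changes several things at once, since the entering group has fewer heavy atoms, fewer hydrogen-bond acceptors and no hydrogen-bond donor, and it also loses the chain between the aromatic carbon and the six-membered non-aromatic ring, so the step cannot be assigned to any one of these differences. No supporting measurement is available to explain the step.

The compounds shown leave open whether the loss follows the amino hydrogen, the ethyl chain or the second ring nitrogen of the departing group. A (2-(piperidin-1-yl)ethyl)amino group, a 4-methylpiperazin-1-yl group placed directly on the same aromatic carbon, or a longer chain ending in the same 4-methylpiperazin-1-yl ring would each separate these features on the core of compound 1.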